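A few compounds are considered here, and "the series" means these few. Any claim that something is new, unique, unknown or untested is made for them only; others in the source may bear on it.

In an ADME assay on HEK-293T cells (Homo sapiens) for cytotoxicity, read by MTT assay, with a stated time of 3 days (on this read-out lower numbers stand for higher toxicity in this test and higher numbers for lower toxicity in this test), compound 1 `CC(C)(C)NC(=O)COC(=O)c1ccc([N+](=O)[O-])o1` gives > 100000 nM, which is a limit of the assay and not a number. Compound 2 `CC(C)(C)N(CCCc1ccccc1)C(=O)COC(=O)c1ccc([N+](=O)[O-])o1`, which adds a phenylpropyl-type chain on the amide-type nitrogen, is reported only as "not active" (no number reported), so it has no single number on this scale. Compound 3 `CC(C)(C)N(CCC(=O)c1ccccc1)C(=O)COC(=O)c1ccc([N+](=O)[O-])o1` differs from it in one place, with benzoyl in place of benzyl on a saturated chain carbon, two bonds along the chain from an amide-type nitrogen. For the measured compounds named here, no measured pair in this small set shows what such a swap does. With compound 2 at "not active" (no number reported), the expected step in this assay is none beyond the usual scatter, and no direction is favoured. For compound 3, the estimated half-maximal cytotoxic concentration is 100000 nM, with an expected range from 40000 nM to 200000 nM.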

Compound 3, half-maximal cytotoxic concentration: "not active" (no number reported)
For compound 3 the study gives words and no number; the estimate stays without a comparison.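

Compound 2 and compound 3 are both reported in words only, as not active, and no step can be read between them in this assay. What benzoyl in place of benzyl does to this read-out stays open, and the only figure shown is a limit: the limit of > 100000 nM in this assay, at which 1 of the 3 values shown sits.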